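Acetylation of the aromatic amine in two amide-linked series

The source may report more compounds than this note shows. Statements on the series, on what has been measured and on what is new or still open speak of the compounds shown alone.

Measured compounds:
compound 1 `COc1ccc(C(=O)Nc2cccc(-c3ccnc4c(N)cccc34)c2)cc1OC` — 9500 nM
compound 2 `COc1ccc(C(=O)Nc2cccc(-c3ccnc4c(NC(C)=O)cccc34)c2)cc1OC` — 5300 nM
compound 3 `Nc1cccc2c(-c3cccc(NC(=O)Nc4ccc(Cl)c(C(F)(F)F)c4)c3)ccnc12` — 3000 nM

All three were tested in a functional assay on A375P cells (Homo sapiens) for antiproliferative activity, read by MTT assay, with a stated time of 48 h; on this read-out lower numbers stand for stronger inhibition and higher numbers for weaker inhibition. Compound 1 carries a free amino group on its core; in this assay compound 1 gives 9500 nM. Compound 2 differs from compound 1 by acetyl in place of hydrogen on a nitrogen on an aromatic ring, and the step is a 1.8-fold lower number from compound 1 to compound 2 (0.25 log units; within the scatter). Compound 3 keeps the same free amine on the same core but carries a urea in place of the amide of compound 1; the difference between the two cores is not broken down here. In this assay compound 3 gives 3000 nM, the lowest of the three numbers, though its gap to compound 2 is within the scatter and only its gap to compound 1 lies beyond it.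

Compound 4 `CC(=O)Nc1cccc2c(-c3cccc(NC(=O)Nc4ccc(Cl)c(C(F)(F)F)c4)c3)ccnc12` has not yet been measured. It differs from compound 3 by acetyl in place of hydrogen on a nitrogen on an aromatic ring, the same change already made from compound 1 to compound 2, at the same kind of place. Within the data shown here, the one measured instance of this change, a 1.8-fold lower number from compound 1 to compound 2 (0.25 log units; within the scatter), was within the scatter, so the expectation for compound 4 rests on that single step carried over to the urea series. For compound 4 in this assay the expected step is a 1.7-fold lower number from compound 3 to compound 4 (0.22 log units; within the scatter), estimated to be of the same size as the earlier one. Compound 4 is therefore estimated at 1800 nM, with a likely range from 800 nM to 4500 nM.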

Compound 4, half-maximal inhibitory concentration: 2500 nM
Compound 4: middle estimate off by 1.4-fold (0.14 log units), on the low side, and the stated range covers the measured number.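

In this assay the new step is a 1.2-fold lower number from compound 3 to compound 4 (0.08 log units; within the scatter) and, like the earlier step on the amide-linked core, it stays within the scatter, so neither core shows a measurable response to acetyl in place of hydrogen on a nitrogen on an aromatic ring. This does not show that the acetamido compounds are better or worse than their amino partners on either core, and two steps of this kind, both small, set no rule for further cores in the series. What can be said is that the change carried from one core to the other without a detectable difference between the two steps: the same change on two cores in this assay, a 1.8-fold lower number (0.25 log units; within the scatter) from compound 1 to compound 2 and a 1.2-fold lower number (0.08 log units; within the scatter) from compound 3 to compound 4, 1.5-fold (0.17 log units) apart, within the scatter of two such steps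

Open questions remain at that same nitrogen, where only hydrogen and acetyl are shown: a longer acyl chain such as butanoyl, a methanesulfonyl group or a simple methyl group might or might not give a step beyond the scatter. From the compounds shown here alone, compound 1 and compound 3 differ in more than one place, so the separate contributions of the urea, the amide and the groups on the far aromatic ring also stay open.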